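A few compounds are considered here, and "the series" means these few. Any claim that something is new, unique, unknown or untested is made for them only; others in the source may bear on it.

Measured so far:
- compound 1, `C=CCn1c(=O)/c(=C\c2cc(F)ccc2C)[nH]c(=O)/c1=C\c1ccccc1OC`: 1000 nM
- compound 2, `COc1ccccc1/C=c1\c(=O)[nH]/c(=C/c2ccccc2Cl)c(=O)n1C`: 100 nM
- compound 3, `C=CCn1c(=O)/c(=C\c2cccc(Br)c2)[nH]c(=O)/c1=C\c1cccc(Br)c1`: "not active" (no number reported)

In a functional assay on U-937 cells (Homo sapiens) for cytotoxicity, read by CCK-8 assay, with a stated time of 72 h (a lower number here means a stronger inhibitor, a higher number a weaker inhibitor), compound 1 gives 1000 nM. Of the two compounds with a number, compound 1 has the highest value, so it is the weaker of the pair: compound 2 gives 100 nM, a gap beyond the usual scatter. Compound 3 gave no number at all in this assay and was reported as not active.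

The new compound 4, `C=CCn1c(=O)/c(=C\c2ccccc2F)[nH]c(=O)/c1=C\c1ccccc1OC`, keeps the core of compound 1 and differs in one place: 2-fluorophenyl in place of 5-fluoro-2-methylphenyl on a double-bonded chain carbon bound to an aromatic carbon. So the 5-fluoro-2-methylphenyl group leaves and a 2-fluorophenyl group enters on a double-bonded chain carbon bound to an aromatic carbon. Within the data shown here, no measured pair among the three known compounds shows this exact change, so there is no direct guide to its size. With the core unchanged, the step is expected to be small, most likely within the scatter, and without a clear direction; a modest estimate is a 1.3-fold lower number from compound 1 to compound 4 (0.10 log units; within the scatter). Compound 4 is therefore estimated at 800 nM in this assay, within a range from 300 nM to 3000 nM.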

Compound 4, half-maximal inhibitory concentration: 5500 nM
Estimate against measurement, compound 4: 6.9-fold (0.84 log units) below, and the stated range ends below it.
By their numbers in this assay, from the lowest: compound 2; then compound 1; then compound 4.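

In this assay, putting 2-fluorophenyl in place of 5-fluoro-2-methylphenyl on a double-bonded chain carbon bound to an aromatic carbon gives a 5.5-fold higher number from compound 1 to compound 4 (0.74 log units; beyond the scatter), so the number at this place responds clearly to a modest change of group. Both groups have one six-membered aromatic ring of carbon only and one fluorine, yet the swap removes the methyl and also moves the fluorine, so these two changes cannot be told apart here. Nothing measured here bears on why the number rises.

Going by these compounds, it remains open whether the methyl, the place of the fluorine or both account for this step, which a plain 2-methylphenyl or 3-fluorophenyl group at this place could help to separate. On these data alone, how an amine or a carboxylic acid on this aromatic ring would behave also remains unknown.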